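The compounds below may be only part of what the source reports. "The series", "measured", "known", "first", "only" and "open" are said of these compounds alone.

Values in a functional assay for inhibition, with Rattus norvegicus as the target; on this read-out lower numbers stand for stronger inhibition and higher numbers for weaker inhibition
- compound 1 `CC(C)(C)/N=c1\c(O)c(O)\c1=N/c1ccc(C#N)cc1` - 560 nM
- compound 2 `CC(C)C(C)/N=c1\c(O)c(O)\c1=N/c1ccc(C#N)cc1` - 1900 nM
- compound 3 `CCC(C)/N=c1\c(O)c(O)\c1=N/c1ccc(C#N)cc1` - 2100 nM

Compound 3 and compound 2 sit together (a 1.1-fold higher number from compound 2 to compound 3 (0.04 log units; within the scatter)), and both carry higher numbers than compound 1 (a 3.4-fold higher number from compound 1 to compound 2 (0.53 log units; beyond the scatter)) (a 3.8-fold higher number from compound 1 to compound 3 (0.57 log units; beyond the scatter)). Compound 4 `CC(C)/N=c1\c(O)c(O)\c1=N/c1ccc(C#N)cc1` brings hydrogen in place of methyl on a saturated chain carbon, two bonds along the chain from a double-bonded nitrogen (hydrogen in place of methyl on a saturated chain carbon, two bonds along the chain from a double-bonded nitrogen; sec-butyl to isopropyl). The closest measured precedent is the step between compound 2 and compound 3, also hydrogen in place of methyl, which stayed within the scatter. The steps from compound 1 were modest and leave room for a slight drift upward, so no step beyond the scatter is expected. The expected result in this assay is a 1.3-fold higher number from compound 3 to compound 4 (0.12 log units; within the scatter) as the estimated step. Compound 4 is estimated at 2800 nM (expected range 1200 nM to 6500 nM).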

Compound 4, half-maximal inhibitory concentration: 13700 nM
Estimate against measurement, compound 4: 4.9-fold (0.69 log units) below; the whole stated range lies below it.
By their numbers in this assay, from the lowest: compound 1; then compounds 2 and 3 (each within the scatter of the next); then compound 4.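

Hydrogen in place of methyl is not a neutral change at this position in this assay: sec-butyl to isopropyl gives a 6.5-fold higher number from compound 3 to compound 4 (0.81 log units; beyond the scatter). Isopropyl also stands clear of the other two groups on the double-bonded nitrogen, with a 7.2-fold higher number from compound 2 to compound 4 (0.86 log units; beyond the scatter) against 1,2-dimethylpropyl and a 24-fold higher number from compound 1 to compound 4 (1.39 log units; beyond the scatter) against tert-butyl. The size of this change therefore depends on the group that carries it: the same change on two cores in this assay, a 1.1-fold higher number (0.04 log units; within the scatter) from compound 2 to compound 3 and a 24-fold higher number (1.39 log units; beyond the scatter) from compound 1 to compound 4, 22-fold (1.35 log units) apart, beyond the scatter of two such steps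

The compounds shown leave open how a straight propyl chain or a cyclopentyl ring on the double-bonded nitrogen would read.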